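Replacing a hydroxyphenyl with pyridyl: expected cytotoxicity

This account rests on a few compounds, and the source may have more. Where it says the series, first, only, none or still open, it means among the compounds named here.

Of the compounds shown here, three sharing one core have been tested in an ADME assay on THP-1 cells (Homo sapiens) for cytotoxicity, read by MTT assay; on this read-out lower numbers stand for higher toxicity in this test and higher numbers for lower toxicity in this test. Compound 1, `Cc1nc(-c2cccnc2)sc1-c1nnc(-c2ccccc2)o1`, gives in this assay only a limit, > 100 ug/mL. Compound 2, `Cc1cccc(-c2nnc(-c3sc(-c4cccnc4)nc3C)o2)c1`, likewise gives only a limit in this assay, > 100 ug/mL. Compound 3, `Cc1nc(-c2cccnc2)sc1-c1nnc(-c2ccc(O)cc2)o1`, also gives only a limit in this assay, > 100 ug/mL. Compound 3 therefore stands exactly where every value shown stands: the limit of > 100 ug/mL in this assay, at which 3 of the 3 values shown sit. The three steps among these compounds, a step that the two limits leave unreadable from compound 1 to compound 2, a step that the two limits leave unreadable from compound 1 to compound 3 and a step that the two limits leave unreadable from compound 2 to compound 3, cannot be read in size, each running from one limit to another.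

Compound 4, `Cc1nc(-c2cccnc2)sc1-c1nnc(-c2cccnc2)o1`, arises from compound 3 by a single change: pyridin-3-yl in place of 4-hydroxyphenyl on an aromatic carbon. The measured steps that bear on this change are the three just named, and none of them yields a readable size; nothing measured here shows any shift in this assay larger than the usual scatter. For compound 4 the step is expected to be a step that the limit leaves unreadable from compound 3 to compound 4, which means that the same outcome, a limit rather than a number, is the most likely result. Compound 4 is expected in this assay to give around 150 ug/mL, within a range from 80 ug/mL to 300 ug/mL.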

Compound 4, half-maximal cytotoxic concentration: > 100 ug/mL
Compound 4 ended at the assay's limit (the forecaster's own chance of this, stated with the estimate: 85%); the middle value is on the limit's open side.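

Compound 4, like compound 1, compound 2 and compound 3, gives only a limit in this assay, so none of the steps leading to compound 4 can be read in size: the limit of > 100 ug/mL in this assay, at which 4 of the 4 values shown sit.

The compounds shown leave open how far apart these four truly lie in this test, and whether any change on the shared core would yield a number rather than a limit.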